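Chloro to Methyl on the Chain of Compound 3

The source may hold more compounds than are shown below. What is called first, only, known or untested is meant among the compounds shown, and "the series" means these compounds.

Compound 3 `O=C1O[C@H]([C@@H](O)Cn2cc(CCCCl)nn2)C(OCc2ccccc2)=C1OCc1ccccc1` stands at the weakest end of the three measured compounds: in a functional assay on CFPAC-1 cells (Homo sapiens) for antiproliferative activity, read by MTT assay, with a stated time of 72 h (on this read-out lower numbers stand for stronger inhibition and higher numbers for weaker inhibition), compound 3 gives 58800 nM, whereas compound 1 `O=C1O[C@H]([C@@H](O)Cn2cc(CNS(=O)(=O)c3ccc(F)cc3)nn2)C(OCc2ccccc2)=C1OCc1ccccc1` gives 34700 nM and compound 2 `COc1ccc(-c2cn(C[C@H](O)[C@H]3OC(=O)C(OCc4ccccc4)=C3OCc3ccccc3)nn2)cc1` gives 26000 nM. The steps of a 1.7-fold higher number from compound 1 to compound 3 (0.23 log units; within the scatter) and a 2.3-fold higher number from compound 2 to compound 3 (0.35 log units; beyond the scatter) show that swapping the aromatic or sulfonamide-bearing substituents for a short chlorinated chain cost little. Going by the values given here, compound 4 `CCCCc1cn(C[C@H](O)[C@H]2OC(=O)C(OCc3ccccc3)=C2OCc2ccccc2)nn1` differs from compound 3 only by methyl in place of chloro on a saturated chain carbon, three bonds along the chain from an aromatic carbon; no measured step involves such a swap of a single chain atom, so the nearest guidance is the small size of every step seen so far. A change of no more than the scatter is therefore expected, and compound 4 is estimated at 60000 nM, between 25000 nM and 140000 nM, a step of a 1.0-fold higher number from compound 3 to compound 4 (0.01 log units; within the scatter).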

Compound 4, half-maximal inhibitory concentration: 73200 nM
Compound 4: middle estimate off by 1.2-fold (0.09 log units), on the low side, within the range that was stated.
By their numbers in this assay, from the lowest: compounds 2, 1, 3 and 4 (each within the scatter of the next, the first and the last beyond it).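

Methyl in place of chloro, three bonds along the chain from an aromatic carbon, gives a 1.2-fold higher number from compound 3 to compound 4 (0.10 log units; within the scatter) in this assay and so leaves the number within the scatter. The all-carbon chain also gives a 2.8-fold higher number from compound 2 to compound 4 (0.45 log units; beyond the scatter) and a 2.1-fold higher number from compound 1 to compound 4 (0.32 log units; beyond the scatter), and this last step lies beyond the scatter, which the step to the chlorinated chain from the same sulfonamide did not. No evidence bears on what lies behind these small steps.

From the compounds shown here alone, whether a hydroxyl, an amine or a carboxylic acid at this chain end, or a longer chain, would lower the number remains open.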